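This account rests on a few compounds, and the source may have more. Where it says the series, first, only, none or still open, it means among the compounds named here.

Values in an ADME assay on WI-38 cells (Homo sapiens) for cytotoxicity, read by MTT assay, with a stated time of 72 h; on this read-out higher numbers stand for weaker inhibition and lower numbers for stronger inhibition:
- compound 1 `O=C(CCc1cccc2c1B(O)OC2)Nc1cccc(Br)c1`: 20000 nM
- compound 2 `CC(C)c1cccc(NC(=O)CCc2cccc3c2B(O)OC3)c1`: 22000 nM
- compound 3 `O=C(CCc1cccc2c1B(O)OC2)Nc1cccc(-c2ccc(Cl)cc2)c1`: 9800 nM

Compound 3 gives the lowest number of the three. Compound 4 `COc1cc(OC)cc(-c2cccc(NC(=O)CCc3cccc4c3B(O)OC4)c2)c1` places 3,5-dimethoxyphenyl in place of 4-chlorophenyl on an aromatic carbon.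

Among the compounds with values here, two measured steps bear on this, a 2.0-fold lower number from compound 1 to compound 3 (0.31 log units; beyond the scatter) and a 2.2-fold lower number from compound 2 to compound 3 (0.35 log units; beyond the scatter). Both are modest, and a 1.1-fold higher number from compound 1 to compound 2 (0.04 log units; within the scatter) stays within the scatter. No measured step exchanges one phenyl group for another, so the series offers little reason to expect a large move in this assay. No change beyond the scatter is expected, and the estimated step is a 1.1-fold higher number from compound 3 to compound 4 (0.05 log units; within the scatter). The estimate for compound 4 is 11000 nM, with an expected range of 5000 nM to 22000 nM.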

Compound 4, half-maximal inhibitory concentration: 1700 nM
Compound 4: the middle estimate sits 6.5-fold (0.81 log units) above what was measured, and the stated range ends above it.
By their numbers in this assay, from the lowest: compound 4; then compound 3; then compounds 1 and 2 (each within the scatter of the next).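

Within the data shown here, at this position the choice of aryl group matters in this assay, not only the presence of one: 3,5-dimethoxyphenyl in place of 4-chlorophenyl gives a wider move (a 5.8-fold lower number from compound 3 to compound 4 (0.76 log units; beyond the scatter)) than any step among the earlier compounds. Against the smaller groups the steps are large (a 12-fold lower number from compound 1 to compound 4 (1.07 log units; beyond the scatter); a 13-fold lower number from compound 2 to compound 4 (1.11 log units; beyond the scatter)), while 4-chlorophenyl gave only modest steps from the same compounds. Nothing available explains this drop.

Open, on these data alone, is whether one methoxy group would give the same number as two, and how an amine or carboxylic acid on that phenyl ring would read.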